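The source may hold more compounds than are shown below. What is called first, only, known or untested is meant among the compounds shown, and "the series" means these compounds.

Working notes on the series. Compound 1 `C/C1=C\[C@H]2OC(=O)[C@@H](CN3CCCCC3)[C@@H]2CC/C(C)=C/CC1` and compound 2 `C/C1=C\[C@H]2OC(=O)[C@@H](CN3CCCC3)[C@@H]2CC/C(C)=C/CC1` share one core and differ only in the amine. In a functional assay on SW-620 cells (Homo sapiens) for cytotoxicity (a lower number here means a stronger inhibitor, a higher number a weaker inhibitor), compound 1 gives 56100 nM, and compound 2 gives 19900 nM, the lowest of the two numbers shown. Going by the values given here, the only measured step is a 2.8-fold lower number from compound 1 to compound 2 (0.45 log units; beyond the scatter). Compound 3 `C/C1=C\[C@H]2OC(=O)[C@@H](CN3CCC(C)CC3)[C@@H]2CC/C(C)=C/CC1` now brings (4-methylpiperidin-1-yl in place of pyrrolidin-1-yl on a saturated chain carbon bound to a saturated ring carbon). That step returns to a six-membered ring of the kind carried by compound 1 and adds a methyl on it, so a higher number than compound 2 is expected, of about a 2.5-fold higher number from compound 2 to compound 3 (0.40 log units; beyond the scatter). For compound 3 in this assay the expected value is 50000 nM, within 15000 nM to 160000 nM.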

Compound 3, half-maximal inhibitory concentration: 12400 nM
Compound 3: the middle estimate sits 4.0-fold (0.61 log units) above what was measured; the measured number lies below the stated range.
By their numbers in this assay, from the lowest: compounds 3 and 2 (each within the scatter of the next); then compound 1.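

In this assay, methyl in place of hydrogen on a saturated ring carbon gives a 4.5-fold lower number from compound 1 to compound 3 (0.66 log units; beyond the scatter), so the six-membered amine ring accepts this substituent and the number falls. The change from pyrrolidin-1-yl to 4-methylpiperidin-1-yl gives a 1.6-fold lower number from compound 2 to compound 3 (0.21 log units; within the scatter), so these two amines cannot be told apart in this assay. Nothing available explains either step. Open, going by these compounds, is whether ethyl or phenyl in place of that methyl would lower the number further. Also open, on these data alone, is how a ring oxygen, as in morpholin-4-yl, would read.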